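This account rests on a few compounds, and the source may have more. Where it says the series, first, only, none or still open, it means among the compounds named here.

Values in a functional assay on HL-60 cells (Homo sapiens) for inhibition, read by MTT assay, with a stated time of 72 h; on this read-out higher numbers stand for weaker inhibition and lower numbers for stronger inhibition:
- Compound 1 `CCc1nc(-c2ccccc2F)c(C(=O)N2CCN(c3cccc(Cl)c3)CC2)o1`: 139 nM
- Compound 2 `CCc1nc(-c2ccccc2Cl)c(C(=O)N2CCN(c3cccc(Cl)c3)CC2)o1`: 98.9 nM
- Compound 3 `CC(C)(C)c1nc(-c2ccccc2F)c(C(=O)N2CCN(c3cccc(Cl)c3)CC2)o1`: > 1000 nM

Only two of these entries are true numbers, and they lie close together: chloro in place of fluoro on an aromatic carbon gives a 1.4-fold lower number from compound 1 to compound 2 (0.15 log units; within the scatter). For compound 3, > 1000 nM is a limit and not a number. Its comparison with compound 1 still tells something: tert-butyl in place of ethyl on an aromatic carbon gives an at least 7.1-fold higher number from compound 1 to compound 3 (0.85 log units; beyond the scatter).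

Compound 4 `CCc1nc(-c2ccccc2F)c(C(=O)N2CCN(c3cccc(OC)c3)CC2)o1` keeps the core of compound 1 and alters a single group, with 3-chlorophenyl becoming 3-methoxyphenyl. This puts methoxy in place of chloro on an aromatic carbon, meta to a large group (methoxy in place of chloro on an aromatic carbon). Neither measured step touches this spot, so both offer only indirect guidance. One change left the number within the scatter and the other moved it well beyond, so the range has to stay wide. The expected outcome is a 1.4-fold higher number from compound 1 to compound 4 (0.16 log units; within the scatter), which would be a small rise in the number at most, with no firm change beyond the scatter anticipated. For compound 4 the estimated value is 200 nM, with an expected range from 60 nM to 700 nM.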

Compound 4, half-maximal inhibitory concentration: 607 nM
Beside the measured number, compound 4's estimate is 3.0-fold (0.48 log units) below it; measured number inside the range.
By their numbers in this assay, from the lowest: compounds 2 and 1 (each within the scatter of the next); then compound 4. At a limit, above all of these: compound 3.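

Earlier steps changed only the fluoro and ethyl groups, so they said nothing about the 3-chlorophenyl group. In this assay, 3-methoxyphenyl in place of 3-chlorophenyl gives a 4.4-fold higher number from compound 1 to compound 4 (0.64 log units; beyond the scatter), so this spot on the aromatic ring does respond to what it carries, and the change swaps one heavy atom for two and adds a hydrogen-bond acceptor, though a single step cannot say which of these differences counts. Compound 4 still gives a true number, whereas the entry for compound 3 is a limit, the only one in this set: the limit of > 1000 nM in this assay, at which 1 of the 4 values shown sits.

The compounds shown leave open whether the higher number comes from adding the methoxy or from removing the chloro, and a methyl, a fluoro or an amine on the same aromatic carbon would help to separate those two readings. They also leave open whether the same swap would give a similar step on compound 2, which carries chloro in place of fluoro.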